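Replacing an aryl group with an amide at the amine

The compounds below may be only part of what the source reports. "The series", "measured", "known", "first", "only" and "open" are said of these compounds alone.

Three compounds measured in a functional assay on cardiac atrium for antagonist activity at histamine H2 receptor (Cavia porcellus) (on this read-out higher numbers stand for higher potency (the scale is a negative logarithm) and lower numbers for lower potency), share a cyanoguanidine or amide link to a piperidinylmethyl-phenoxypropyl chain. Compound 1 `Nc1ccc(C(=O)NCCCOc2cccc(CN3CCCCC3)c2)cc1` gives 6.82 in this assay. Compound 2 `N#CN/C(=N\CCNc1ccc(N=[N+]=[N-])cc1[N+](=O)[O-])NCCCOc1cccc(CN2CCCCC2)c1` gives 7.39 in this assay. Compound 3 `N#CN/C(=N\CCNC(=O)c1ccccc1)NCCCCOc1cccc(CN2CCCCC2)c1` gives 7.67 in this assay.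

Among these three numbers compound 2 stands second highest. Its nearest neighbour is compound 3, whose value lies above it by an amount within the usual scatter, so no order between compound 2 and compound 3 can be claimed. Its furthest neighbour is compound 1, whose value lies below it by an amount beyond the scatter, so compound 2 is the more potent of that pair.

Compound 4 `N#CN/C(=N\CCNC(=O)CCc1ccccc1)NCCCOc1cccc(CN2CCCCC2)c1` has not yet been measured in this assay. It differs from compound 2 in one place: phenethylcarbonyl in place of 4-azido-2-nitrophenyl on an amine nitrogen. For the measured compounds named here, no measured step of this kind is available, so the size of the change can only be estimated. Compound 4 is expected to give 7.5 in this assay, with a range from 7 to 8. This corresponds to an expected step of a number 0.11 log units higher from compound 2 to compound 4 (within the scatter), small and within the scatter, resting on the observation that compound 3, which also carries an amide on that amine, gives 7.67.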

Compound 4, negative logarithm of the antagonist equilibrium constant: 6.27
Compound 4: middle estimate off by 1.23 log units, on the high side, outside the stated range (below it).
By their numbers in this assay, from the lowest: compound 4; then compound 1; then compounds 2 and 3 (each within the scatter of the next).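

In this assay, for the compounds shown here, the exchange at the amine nitrogen gives a large step, a number 1.12 log units lower from compound 2 to compound 4 (beyond the scatter), and this is the first measured step at this position, so the position does not treat every group alike. The exchange removes 4-azido-2-nitrophenyl, with its 3 hydrogen-bond acceptors and 3 double bonds outside aromatic rings, and brings in phenethylcarbonyl, with 1 hydrogen-bond acceptor and 1 double bond outside aromatic rings; both groups hold one six-membered aromatic ring of carbon only, so that ring alone does not preserve the 7.39 of compound 2. No measurement at hand explains the drop or assigns it to one part of the exchange.

The compounds shown leave open whether the drop goes with the carbonyl on the amine nitrogen or with the rest of the entering group, a question that a phenylacetyl group or a plain phenyl group at this nitrogen would help to separate. Compound 3 differs from compound 4 in more than one place, so the role of the amide at this position also remains unsettled.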